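The source may report more compounds than this note shows. Statements on the series, on what has been measured and on what is new or still open speak of the compounds shown alone.

Compound 1, `CCOC(=O)c1c(C)nc(NCCCNc2ccnc3cc(Cl)ccc23)nc1-c1ccccc1` — in an ADME assay on HeLa cells (Homo sapiens) for cytotoxicity, read by microscopy (a higher number here means that more compound is tolerated, a lower number that less compound is tolerated), compound 1 gives > 100000 nM, which is a limit of the assay.
Compound 2, `CCOC(=O)c1c(C)nc(NCCCCNc2ccnc3cc(Cl)ccc23)nc1C` — in this assay compound 2 gives >= 20000 nM, also a limit of the assay.
Compound 3, `Cc1nc(NCCCNc2ccnc3cc(Cl)ccc23)nc(-c2cccc([N+](=O)[O-])c2)c1C(=O)OC(C)C` — in this assay compound 3 gives 20000 nM.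

Compound 1 stands at the limit of > 100000 nM in this assay, at which 1 of the 3 values shown sits, so only a limit is known for it. Compound 4, `CCOC(=O)c1c(C)nc(NCCCNc2ccnc3cc(Cl)ccc23)nc1C`, differs from compound 1 by methyl in place of phenyl on an aromatic carbon. For the measured compounds named here, no step between measured compounds is available to size this change. Compound 2 carries the same methyl group and sits at the limit of >= 20000 nM in this assay, at which 1 of the 3 values shown sits. On that basis compound 4 is expected to stay well tolerated, with the step of an at least 2.0-fold lower number from compound 1 to compound 4 (0.30 log units; that floor lies within the scatter) expected to be at most a modest fall, possibly none beyond the scatter. Compound 4 is estimated at 50000 nM, between 15000 nM and 150000 nM.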

Compound 4, minimum cytotoxic concentration: > 100000 nM
Compound 4: no number, only a limit; the forecaster's own chance of this, stated with the estimate: 60%; middle value at least 2.0-fold (0.30 log units) from the limit.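

For the compounds shown here, compound 1 and compound 4 both sit at a limit of this assay, so no step between them can be read. The compounds shown leave open whether methyl in place of phenyl changes the tolerated concentration at all.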